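The compounds below may be only part of what the source reports. "The series", "measured", "known", "first", "only" and "open" are said of these compounds alone.

Measured compounds:
Compound 1, `Fc1cccc(CSc2nc(-c3ccc(Br)cc3)cc(-c3ccc(Br)cc3)n2)c1`, 19000 nM in an assay on isolated protein for inhibition of Alpha glucosidase (Homo sapiens), read by spectrophotometry, with stated times of 15 min and 30 min; a higher number here means a weaker inhibitor, a lower number a stronger inhibitor.
Compound 2, `Clc1ccccc1CSc1nc(-c2ccc(Br)cc2)cc(-c2ccc(Br)cc2)n1`, 19000 nM in this assay.
Compound 3, `Cc1ccc(-c2cc(-c3cccc(Br)c3)nc(SCc3ccccc3Cl)n2)cc1`, 19000 nM in this assay.

The three measured compounds share a benzylsulfanyl group on a common core and are all read in this assay, where compound 1, compound 2 and compound 3 each give the same half-maximal inhibitory concentration at the digits recorded, all three lying within the scatter of one another. Compound 1 and compound 2 differ in one place only: 3-fluorophenyl in place of 2-chlorophenyl on a saturated chain carbon bound to a sulfur. That change produced no change at the digits printed from compound 2 to compound 1 (within the scatter). Compound 3 carries a different core from compound 2; the difference between the two cores is not broken down here, and what can be said is that their two values are level.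

Compound 4, `Cc1ccc(-c2cc(-c3cccc(Br)c3)nc(SCc3cccc(F)c3)n2)cc1`, has not yet been measured in this assay. It differs from compound 3 in one place: 3-fluorophenyl in place of 2-chlorophenyl on a saturated chain carbon bound to a sulfur. This is the same change that turned compound 2 into compound 1, made at the same place on the chain carbon bound to sulfur, though here on the core of compound 3 rather than that of compound 2. Because no change at the digits printed from compound 2 to compound 1 (within the scatter) on the other core showed no change within the scatter, the same change is expected to leave compound 4 level with compound 3, and the estimated step is no change at the digits printed from compound 3 to compound 4 (within the scatter). Compound 4 is therefore estimated to give 19000 nM in this assay, with an expected range from 9000 nM to 40000 nM.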

Compound 4, half-maximal inhibitory concentration: 19000 nM
For compound 4 middle estimate and measured number coincide at the digits printed; the measured number falls inside the stated range.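

In this assay, putting 3-fluorophenyl in place of 2-chlorophenyl on a saturated chain carbon bound to a sulfur gave no change at the digits printed from compound 3 to compound 4 (within the scatter). The same change therefore reads alike on the core of compound 2 and on the core of compound 3, so in this small set its outcome carried over from one core to the other: the same change on two cores in this assay, no change at the digits printed (within the scatter) from compound 2 to compound 1 and no change at the digits printed (within the scatter) from compound 3 to compound 4, 1.0-fold (0.00 log units) apart, within the scatter of two such steps

Among the compounds shown here, this agreement rests on only two cores and one pair of groups. Neither step moved the value. The agreement shows that a null result recurred, not that a change with a measurable effect would carry over in the same way; nor does it show that the outcome would hold on any further core.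

The compounds shown leave open whether anything on the benzyl group can move the value in this assay, since only 2-chlorobenzyl and 3-fluorobenzyl appear on the sulfur. They also leave open what an amine or a carboxylic acid on that phenyl ring, or a longer chain joining the ring to the sulfur, would do on either core.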